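The source may report more compounds than this note shows. Statements on the series, on what has been measured and on what is new or still open speak of the compounds shown alone.

Measured compounds:
Compound 1 `CN(Cc1ccc(Oc2ccccc2)cc1)Cc1cn(C)c2ccc(CNc3ccc(F)cc3)cc12`, in a functional assay on PC-3 cells (Homo sapiens) for antiproliferative activity, read by MTT assay, with a stated time of 72 h (a higher number here means a weaker inhibitor, a lower number a stronger inhibitor), compound 1 gives 56000 nM.
Compound 2 `CN(Cc1ccc(-c2ccccc2)cc1)Cc1cn(C)c2ccc(CNc3ccc(F)cc3)cc12`, in this assay compound 2 gives 84300 nM.

Among the measured compounds shown here, compound 2 holds the higher of the two numbers so far, but its nearest neighbour is compound 1, and the step of a 1.5-fold higher number from compound 1 to compound 2 (0.18 log units; within the scatter) lies within the scatter, so the two compounds cannot be separated on these data.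

Compound 3 `CN(Cc1ccc(-c2ccccc2)cc1)Cc1cn(C)c2ccc(C(=O)Nc3ccc(F)cc3)cc12` is not yet measured. It differs from compound 2 by (4-fluorophenyl)carbamoyl in place of ((4-fluorophenyl)amino)methyl on an aromatic carbon. For the measured compounds named here, the only measured step, from compound 1 to compound 2, concerns the phenoxy-to-phenyl exchange on the other side of the shared core and does not touch the linker that is changed here; it was within the scatter. Going by the values given here, no measured step bears on the amine-to-amide exchange, so there is no basis for expecting a shift in this assay in either direction, and the working expectation is a step no larger than the scatter, a 1.1-fold lower number from compound 2 to compound 3 (0.02 log units; within the scatter), with a wide range to reflect the absence of a precedent.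

Compound 3 is therefore estimated at 80000 nM in this assay, with a range from 25000 nM to 250000 nM.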

Compound 3, half-maximal inhibitory concentration: > 100000 nM
Compound 3: no number, only a limit; the forecaster's own chance of this, stated with the estimate: 25%; middle value at least 1.2-fold (0.09 log units) away from the limit.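

Compound 3 gives no number in this assay, only a limit of the assay: the limit of > 100000 nM in this assay, at which 1 of the 3 values shown sits. Read against that limit, placing (4-fluorophenyl)carbamoyl on the aromatic carbon that held ((4-fluorophenyl)amino)methyl gives an at least 1.1-fold higher number from compound 2 to compound 3 (0.07 log units; that floor lies within the scatter), so the true size of the step remains unknown and its floor cannot separate the two compounds. Among the compounds shown here, this is the first measured change at this position, as the earlier pair differed only at the phenoxy or phenyl group on the other side of the shared core, and the limit gives no sign that the carbamoyl linker yields a stronger inhibitor than the aminomethyl linker of compound 2 in this assay.

The compounds shown leave open how far beyond its limit compound 3 lies, and whether the same linker exchange would read the same way with the phenoxy group of compound 1 in place of the phenyl group. They also leave open what a sulfonamide linker or a longer methylene chain would give on this aromatic carbon of the shared core.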